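A few compounds are considered here, and "the series" means these few. Any claim that something is new, unique, unknown or untested is made for them only; others in the source may bear on it.

Measured compounds in an ADME assay on A549 cells (Homo sapiens) for cytotoxicity, read by resazurin assay, with a stated time of 48 h; on this read-out lower numbers stand for higher toxicity in this test and higher numbers for lower toxicity in this test:

Compound 1, `CCNc1ccc(NC(=O)c2cc(Cl)ccc2O)c(Cl)c1`, gives 30200 nM.
Compound 2, `CCCCCCC(C)Nc1ccc(NC(=O)c2cc(Cl)ccc2O)c(Cl)c1`, gives 23500 nM.
Compound 3, `CC1(ON(c2ccc(NC(=O)c3cc(Cl)ccc3O)c(Cl)c2)C2(C)CCCC2)CCCC1`, gives 18000 nM.

All three compounds share the same core, a salicylanilide bearing two chlorine atoms, and differ only in the group carried by the nitrogen on the aromatic ring. The three numbers fall within the usual scatter of one another, so compound 2 stands apart from neither compound 1 nor compound 3 in this assay. Going by the values given here, the one step that can be followed within the set, a 1.3-fold lower number from compound 1 to compound 2 (0.11 log units; within the scatter), shows that adding a hexyl chain left the read-out essentially where it was.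

Compound 4, `O=C(Nc1ccc(NCc2ccccc2)cc1Cl)c1cc(Cl)ccc1O`, is the compound now in question. It differs from compound 2 in one place: benzyl in place of 1-methylheptyl on a nitrogen on an aromatic ring. Among the compounds with values here, no measured step exchanges a saturated chain for an aromatic ring here, so the only guidance is that the set as a whole has so far been flat in this assay, whatever sat on that nitrogen. Compound 4 is therefore expected to show no step beyond the scatter, with a 1.1-fold lower number from compound 2 to compound 4 (0.03 log units; within the scatter).

For compound 4 the estimate in this assay is 22000 nM, within a range of 9000 nM to 50000 nM.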

Compound 4, half-maximal cytotoxic concentration: 19700 nM
Estimate against measurement, compound 4: 1.1-fold (0.05 log units) above, and the stated range covers the measured number.
By their numbers in this assay, from the lowest: compounds 3, 4, 2 and 1 (each within the scatter of the next).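

Going by these compounds alone, compound 4 is the first in the set to carry an aromatic ring on this nitrogen by way of a benzyl group, and in (this assay) swapping 1-methylheptyl for benzyl leaves the read-out within the scatter (a 1.2-fold lower number from compound 2 to compound 4 (0.08 log units; within the scatter)). Within the data shown here, the comparison with the small chain of compound 1 also stays within the scatter (a 1.5-fold lower number from compound 1 to compound 4 (0.19 log units; within the scatter)), so for these compounds neither a branched saturated chain nor a benzyl group separates from the other groups on this nitrogen, and no compound here goes against that flat picture. No supporting measurement is available to explain why this position behaves so evenly in this test.

The compounds shown all keep an uncharged carbon group on this nitrogen, so it remains open whether a chain ending in an amine or a carboxylic acid would move the number beyond the scatter. On these data alone, it also remains open whether a benzyl ring bearing a nitrile or a hydroxyl group would stay as flat as the plain benzyl group of compound 4.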